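The source may hold more compounds than are shown below. What is called first, only, known or untested is meant among the compounds shown, and "the series" means these compounds.

Working notes on the series, read in a functional assay on MDA-MB-231 cells (Homo sapiens) for inhibition, read by CCK-8 assay, with a stated time of 48 h; a higher number here means a weaker inhibitor of growth, a lower number a stronger inhibitor of growth. Compound 1 (`CN1CCN(c2ccc(Nc3ncc(Cl)c(NCc4ccccc4)n3)nc2)CC1`) gives 24800 nM, and compound 2 (`CN1CCN(c2ccc(Nc3ncc(Cl)c(Nc4ccc(C(C)(C)C)cc4)n3)nc2)CC1`) gives 16200 nM. Among the measured compounds shown here, these are the only two numbers so far, and they lie within the scatter of each other, so compound 2 cannot be ranked against compound 1.

Compound 3 (`COc1ccc(Nc2nc(Nc3ccc(N4CCN(C)CC4)cn3)ncc2Cl)cc1`) differs from compound 2 in one place: methoxy in place of tert-butyl on an aromatic carbon.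

For the measured compounds named here, the only measured step is a 1.5-fold lower number from compound 1 to compound 2 (0.18 log units; within the scatter), which stays within the scatter. It bears on the change only loosely: it brought in the 4-(tert-butyl)phenyl group in place of benzyl, and it did not vary the group now leaving. Going by the values given here, no measured pair compares tert-butyl with methoxy. On that one small step, no change beyond the scatter is expected in this assay, and no direction is favoured. The reference point stays compound 2 at 16200 nM.

The expected step is a 1.1-fold higher number from compound 2 to compound 3 (0.05 log units; within the scatter), within the scatter. For compound 3 the estimate is 18000 nM, with an expected range of 8000 nM to 40000 nM.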

Compound 3, concentration for 50% growth inhibition: 8020 nM
The estimate for compound 3 lay 2.2-fold (0.35 log units) above the measured number, and the stated range covers the measured number.
By their numbers in this assay, from the lowest: compound 3; then compounds 2 and 1 (each within the scatter of the next).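

In this assay, methoxy in place of tert-butyl on an aromatic carbon gives a 2.0-fold lower number from compound 2 to compound 3 (0.31 log units; beyond the scatter), a modest step beyond the scatter, so the group at this position can shift the number measurably. Against benzyl, 4-methoxyphenyl gives a 3.1-fold lower number from compound 1 to compound 3 (0.49 log units; beyond the scatter), also modest and beyond the scatter, whereas 4-(tert-butyl)phenyl gave only a 1.5-fold lower number from compound 1 to compound 2 (0.18 log units; within the scatter), which stayed within it; compound 3 therefore has the lowest number of the three, and of the two aryl groups only 4-methoxyphenyl separates from benzyl. No measurement shown here accounts for the lower number of compound 3.

This change alters the heavy-atom count, the atom types and the acceptor count together, and a single pair cannot separate these differences, so it remains unclear which of them goes with the step. As far as these compounds go, it also remains open whether a hydroxyl, a fluorine, a dimethylamino group or a longer alkoxy chain on the same aromatic carbon would extend the step, leave the number within the scatter of compound 3 or reverse the direction.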